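Replacing a hydroxy ester with a sulfonamide on the shared core

The compounds below may be only part of what the source reports. "The series", "measured", "known", "first", "only" and "open" are said of these compounds alone.

Compound 1 `COC(=O)[C@H](O)[C@H]1C(=O)N2C(C(=O)O)=C(C(C)(C)C)O[C@H]12` has a half-life in an ADME assay, in phosphate buffer, at 28 degrees C, at pH 7.0 (on this read-out lower numbers stand for a shorter-lived compound and higher numbers for a longer-lived compound), of 6.7 h. Compound 2 `CC(C)(C)OC(=O)[C@H](O)[C@H]1C(=O)N2C(C(=O)O)=C(C(C)(C)C)O[C@H]12` gives 10.7 h in this assay, and compound 3 `CC(C)(C)C1=C(C(=O)O)N2C(=O)[C@H]([C@@H](O)c3ccc(O)cc3)[C@H]2O1` gives 10.3 h. The steps are a 1.6-fold higher number from compound 1 to compound 2 (0.20 log units; within the scatter), a 1.5-fold higher number from compound 1 to compound 3 (0.19 log units; within the scatter) and a 1.0-fold lower number from compound 2 to compound 3 (0.02 log units; within the scatter), so compound 1 is not set apart from either neighbour. Compound 4 `CC(C)(C)C1=C(C(=O)O)N2C(=O)[C@H](CNS(C)(=O)=O)[C@H]2O1` differs from compound 1 by (methanesulfonamido)methyl in place of hydroxy(methoxycarbonyl)methyl on a saturated ring carbon. The step from compound 1 to compound 3, which also exchanged the ester on that chain carbon, and the step from compound 1 to compound 2 both stayed within the scatter, though neither removed the hydroxy group or introduced a methanesulfonamido group. No step beyond the scatter is therefore expected; the estimated step is a 1.1-fold higher number from compound 1 to compound 4 (0.05 log units; within the scatter). Compound 4 is expected at 7.5 h, within 3.5 h to 16 h.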

Compound 4, half-life: 2.2 h
The estimate for compound 4 lay 3.4-fold (0.53 log units) above the measured number, outside the stated range (below it).
By their numbers in this assay, from the lowest: compound 4; then compounds 1, 3 and 2 (each within the scatter of the next).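

In this assay, within the data shown here, putting (methanesulfonamido)methyl in place of hydroxy(methoxycarbonyl)methyl on this saturated ring carbon gives a 3.0-fold lower number from compound 1 to compound 4 (0.48 log units; beyond the scatter), the only step here beyond the scatter. Among these compounds, the earlier changes all kept the hydroxy group on the chain and stayed within the scatter, so only this exchange shows that the half-life can respond to the group at this position. Nothing available gives a reason for this step. As far as these compounds go, whether the step comes from losing the hydroxy group, losing the ester or gaining the methanesulfonamido group stays open, as does what an amine or a carboxylic acid on the same chain would give.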